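The source may report more compounds than this note shows. Statements on the series, on what has been measured and on what is new or still open speak of the compounds shown alone.

In an ADME assay on L6 cells (Rattus norvegicus) for cytotoxicity (a higher number here means a weaker inhibitor, a lower number a stronger inhibitor), compound 1 (`CN1CCN(CCN2CCC3(N(C)C)CC(c4ccccc4)C2C(c2ccccc2)C3)CC1`) gives 70300 nM as its read-out and compound 2 (`CN1CCN(CCCN2CCC3(N4CCCCC4)CC(c4ccccc4)C2C(c2ccccc2)C3)CC1`) gives 62500 nM as its read-out. For the measured compounds named here, compound 2 therefore stands within the scatter of compound 1, the only other measured compound. Compound 3 (`CN1CCN(CCN2CCC3(N4CCCCC4)CC(c4ccccc4)C2C(c2ccccc2)C3)CC1`) has not been measured and differs from compound 2 in one place: 4-methylpiperazin-1-yl in place of (4-methylpiperazin-1-yl)methyl on a saturated chain carbon, two bonds along the chain from an amine nitrogen in a ring is the change, namely 4-methylpiperazin-1-yl in place of (4-methylpiperazin-1-yl)methyl on a saturated chain carbon, two bonds along the chain from an amine nitrogen in a ring. Cut one bond further out, it reads 3-(4-methylpiperazin-1-yl)propyl to 2-(4-methylpiperazin-1-yl)ethyl. Going by the values given here, no measured step isolates this change, so the data offer no direct guide to its size. With only compound 2 at 62500 nM as the anchor, no step beyond the scatter is expected in this assay for this change, and no direction is favoured. The estimated outcome is a 1.0-fold higher number from compound 2 to compound 3 (0.02 log units; within the scatter) and no more than that. For compound 3 the expected value is 65000 nM with an estimated range from 35000 nM to 120000 nM as the read-out.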

Compound 3, half-maximal inhibitory concentration: 127000 nM
Beside the measured number, compound 3's estimate is 2.0-fold (0.29 log units) below it; the whole stated range lies below it.
By their numbers in this assay, from the lowest: compounds 2, 1 and 3 (each within the scatter of the next, the first and the last beyond it).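

In this assay, for the compounds shown here, the change from 3-(4-methylpiperazin-1-yl)propyl to 2-(4-methylpiperazin-1-yl)ethyl gives a 2.0-fold higher number from compound 2 to compound 3 (0.31 log units; beyond the scatter) as the first step to isolate this chain, and it is a modest step that only just clears the usual scatter. With 2-(4-methylpiperazin-1-yl)ethyl held fixed, piperidin-1-yl in place of dimethylamino on a saturated ring carbon gives a 1.8-fold higher number from compound 1 to compound 3 (0.26 log units; within the scatter) and so does not separate from the scatter in this comparison. Nothing at hand accounts for the step on the chain.

As far as these compounds go, the chain result rests on a single pair carrying piperidin-1-yl on the ring carbon, so it remains open whether the same step appears with dimethylamino or morpholin-4-yl at that place. A longer chain such as 4-(4-methylpiperazin-1-yl)butyl, a shorter one such as (4-methylpiperazin-1-yl)methyl, and a different chain end such as piperidin-1-yl would show whether the read-out follows chain length at all or whether this pair is an isolated case.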